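Trifluoromethoxy for chloro on a diaryl thiourea

This account rests on a few compounds, and the source may have more. Where it says the series, first, only, none or still open, it means among the compounds named here.

Measured compounds:
- compound 1 `CC(C)NC(=O)c1cc(Oc2cccc(NC(=S)Nc3ccc(Cl)cc3)c2)ccn1`: 22100 nM
- compound 2 `O=C(NCc1ccccc1)c1cc(Oc2cccc(NC(=S)Nc3ccc(Cl)cc3)c2)ccn1`: 16500 nM

In a functional assay on HCT-116 cells (Homo sapiens) for cytotoxicity, read by MTT assay, with a stated time of 48 h (on this read-out lower numbers stand for stronger inhibition and higher numbers for weaker inhibition), compound 1 gives 22100 nM and compound 2 gives 16500 nM. Among the measured compounds shown here, the only measured step, a 1.3-fold lower number from compound 1 to compound 2 (0.13 log units; within the scatter), changes the amide substituent alone, so compound 2 stands at the lower of two numbers that lie within the scatter of each other.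

Compound 3 `O=C(NCc1ccccc1)c1cc(Oc2cccc(NC(=S)Nc3ccc(OC(F)(F)F)cc3)c2)ccn1` differs from compound 2 by trifluoromethoxy in place of chloro on an aromatic carbon. For the measured compounds named here, no measured step touches this part of the shared core; the one step known, from the amide side, stayed within the scatter. Without a precedent, a step of no more than the usual scatter is expected in this assay, in no firm direction. Compound 3 is therefore estimated at 14000 nM, between 5000 nM and 40000 nM, meaning an expected step of a 1.2-fold lower number from compound 2 to compound 3 (0.07 log units; within the scatter).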

Compound 3, half-maximal inhibitory concentration: 7400 nM
For compound 3 the middle estimate is 1.9-fold (0.28 log units) above the measured one; low and high end bracket the measured number.
By their numbers in this assay, from the lowest: compound 3; then compounds 2 and 1 (each within the scatter of the next).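

In this assay, replacing 4-chlorophenyl with 4-(trifluoromethoxy)phenyl gives a 2.2-fold lower number from compound 2 to compound 3 (0.35 log units; beyond the scatter), a modest change but the only step shown that lies beyond the scatter. The earlier step, on the amide substituent, stayed within the scatter, so this aryl substituent on the thiourea is the one place in the series where a change has been seen to shift the number. No available evidence bears on why this replacement has that effect.

From the compounds shown here alone, it remains open whether the same replacement would shift the number similarly with the isopropyl amide of compound 1. Also unresolved is how a trifluoromethyl, a methoxy or a fluoro group would compare at this position, or whether an amine or a carboxylic acid would be tolerated there.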